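The source may hold more compounds than are shown below. What is called first, only, known or untested is meant among the compounds shown, and "the series" means these compounds.

Measured compounds: compound 1 `Fc1cccc(-c2cn([C@@H]3CN4CCC3CC4)nn2)c1` gives 2.25 nM; compound 2 `Fc1ccc(COc2cccc(-c3cn([C@@H]4CN5CCC4CC5)nn3)c2)cc1` gives 7.17 nM.

In an assay on HEK293 cells for displacement of a labelled ligand from Neuronal acetylcholine receptor; alpha3/beta4 (Homo sapiens), read by scintillation counting, with a stated time of 120 min (on this read-out lower numbers stand for stronger inhibition and higher numbers for weaker inhibition), compound 2 stands at the higher of the two numbers, the step of a 3.2-fold higher number from compound 1 to compound 2 (0.50 log units; beyond the scatter) being modest. Compound 3 `Fc1ccc(COc2cccc(-c3cn([C@H]4CN5CCC4CC5)nn3)c2)cc1` has the same atoms and bonds as compound 2; (the two compounds have the same atoms and bonds; at least one stereo element is drawn with a configuration in one of them and without one in the other: 1 of 3 stereo elements differ; a stereocentre at a saturated ring carbon is drawn S in compound 2 and R in compound 3). Among the compounds with values here, none of the measured steps involves a change at a stereocentre, so the single known step, a 3.2-fold higher number from compound 1 to compound 2 (0.50 log units; beyond the scatter), does not bear on this change, and the expectation rests on the structural change alone. Compound 3 is therefore estimated at 20 nM, between 5 nM and 90 nM, an expected step of a 2.8-fold higher number from compound 2 to compound 3 (0.45 log units; beyond the scatter) whose direction and size remain uncertain.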

Compound 3, inhibition constant: 1090 nM
Estimate against measurement, compound 3: 55-fold (1.74 log units) below; measured number above the stated range.
By their numbers in this assay, from the lowest: compound 1; then compound 2; then compound 3.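

In this assay the swap of S for R at the saturated ring carbon, with atoms and bonds unchanged, gives a 150-fold higher number from compound 2 to compound 3 (2.18 log units; beyond the scatter) and so far outweighs the modest 3.2-fold higher number from compound 1 to compound 2 (0.50 log units; beyond the scatter) seen on the aromatic carbon. The configuration at this position therefore counts for more here than the (4-fluorobenzyl)oxy group did. The comparison rests on how the two compounds are drawn: the fact that one of compounds 2 and 3 is drawn with a defined configuration and the other without, at the place where they differ.

On these data alone, whether the R configuration costs as much with fluoro on the aromatic carbon stays open. Also open, as far as these compounds go, is how an amine or a carboxylic acid in place of the (4-fluorobenzyl)oxy group would read in this assay.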